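Sulfonyl substituent swap from compound 2 to compound 3

This account rests on a few compounds, and the source may have more. Where it says the series, first, only, none or still open, it means among the compounds named here.

Compound 1 `CCS(=O)(=O)Nc1cc(C2CCCCC2)cc2c1CCCC2c1c[nH]cn1` gives 447 nM in an assay on isolated protein for binding affinity to Alpha-1D adrenergic receptor (Rattus norvegicus), read by radioligand binding; a higher number here means a weaker inhibitor, a lower number a stronger inhibitor. Compound 2 `CCCS(=O)(=O)Nc1cccc2c1CCCC2c1c[nH]cn1` stands only at a limit of this assay, < 10000 nM, so no number is known for it; it sits at the limit of < 10000 nM in this assay, at which 1 of the 2 values shown sits. Compound 3 `CN(C)S(=O)(=O)Nc1cccc2c1CCCC2c1c[nH]cn1` differs from compound 2 by dimethylamino in place of propyl on a sulfonyl sulfur. Among the compounds with values here, no measured step covers such a change here, so no shift beyond the usual scatter is expected in this assay in either direction. Compound 3 is expected at 4000 nM, ranging from 1000 nM to 15000 nM. That estimate means a step that the limit leaves unreadable from compound 2 to compound 3, expected to be small.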

Compound 3, inhibition constant: 1580 nM
For compound 3 the middle estimate is 2.5-fold (0.40 log units) above the measured one; measured number inside the range.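

No step from compound 2 to compound 3 can be read, because compound 2 is held only by a limit: the limit of < 10000 nM in this assay, at which 1 of the 3 values shown sits.

On these data alone, whether dimethylamino in place of propyl on a sulfonyl sulfur shifts the value in this assay stays open.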